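This account rests on a few compounds, and the source may have more. Where it says the series, first, only, none or still open, it means among the compounds named here.

Of the compounds shown here, two have so far been tested in a functional assay on CHO cells for agonist activity at Free fatty acid receptor 1 (Homo sapiens), read by calcium flux; on this read-out higher numbers stand for an effect only at larger amounts of compound and lower numbers for an effect already at smaller amounts. Compound 1 `O=C(O)CCc1ccc(OCc2nnc(C(=O)Nc3ccc(F)cc3)s2)cc1` gives 6640 nM in this assay, and compound 2 `O=C(O)CCc1ccc(OCc2nnc(C(=O)Nc3ccc(Cl)cc3)s2)cc1` gives 3690 nM. Among the measured compounds shown here, the one step between them, a 1.8-fold lower number from compound 1 to compound 2 (0.26 log units; within the scatter), exchanges one halogen for another on the aromatic ring attached to the amide-type nitrogen. On these two numbers compound 2 stands at the lower end, but its gap to compound 1 lies within the scatter, so no order between the two can be claimed.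

Compound 3 `O=C(O)CCc1ccc(OCc2nnc(C(=O)Nc3cccc(Cl)c3)s2)cc1` is the next compound. It differs from compound 2 by 3-chlorophenyl in place of 4-chlorophenyl on an amide-type nitrogen: the chlorine remains, the ring remains, and only the point at which the chlorine sits on that ring changes. For the measured compounds named here, the only measured step concerns a change of halogen, not a move of the chlorine around the ring, so it offers no direct guide to this change. With nothing pointing either way, compound 3 is expected to show no step beyond the scatter in this assay, that is a 1.0-fold higher number from compound 2 to compound 3 (0.00 log units; within the scatter). The estimate for compound 3 is therefore 3700 nM, expected to fall between 1200 nM and 12000 nM.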

Compound 3, half-maximal effective concentration: 10600 nM
Beside the measured number, compound 3's estimate is 2.9-fold (0.46 log units) below it; low and high end bracket the measured number.
By their numbers in this assay, from the lowest: compounds 2, 1 and 3 (each within the scatter of the next, the first and the last beyond it).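

Moving the chlorine on the ring attached to the amide-type nitrogen gives a 2.9-fold higher number from compound 2 to compound 3 (0.46 log units; beyond the scatter) in this assay, the first step in this series that clears the scatter, though only modestly. The earlier exchange of one halogen for another could not show this: here, with the same atoms joined differently, where the chlorine sits on the ring makes a readable difference for this one pair, while the rest of the molecule stays the same. Set against 4-fluorophenyl, the 3-chlorophenyl group gives a 1.6-fold higher number from compound 1 to compound 3 (0.20 log units; within the scatter) so no order can be claimed for that pair, and no measurement available here bears on what lies behind the difference between the two chlorinated compounds.

As far as these compounds go, whether a fluorine moved in the same way, as 3-fluorophenyl in place of 4-fluorophenyl, would give a similar step remains open, so this single pair does not yet make a general rule for the ring. From the compounds shown here alone, it is also open how groups other than halogens, such as a methoxy group or a nitrile, would fare on this ring in either of the two places seen so far.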